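A few compounds are considered here, and "the series" means these few. Any claim that something is new, unique, unknown or untested is made for them only; others in the source may bear on it.

Working notes on the series. All three measured compounds share one core. Compound 1 `COc1ccc2c(c1)OC(c1cc(OC)c(OC)c(OC)c1)C(CO)=C2` carries hydroxymethyl on a double-bonded ring carbon; compound 2 `COc1ccc2c(c1)OC(c1cc(OC)c(OC)c(OC)c1)C(C(=O)N1CCCCC1)=C2` has (piperidin-1-yl)carbonyl there; compound 3 `COc1ccc2c(c1)OC(c1cc(OC)c(OC)c(OC)c1)C(C(=O)Nc1ccccc1)=C2` has phenylcarbamoyl there. In a functional assay for inhibition of nuclear factor NF-kappa-B complex (Homo sapiens) (a higher number here means a weaker inhibitor, a lower number a stronger inhibitor), compound 1 sits at a limit, > 50000 nM. In this assay compound 2 likewise gives only a limit, > 50000 nM. In this assay, for the measured compounds named here, compound 3 gives 17500 nM, the only actual number in the set. The two steps towards compound 3, an at least 2.8-fold lower number from compound 1 to compound 3 (0.45 log units; beyond the scatter) and an at least 2.8-fold lower number from compound 2 to compound 3 (0.45 log units; beyond the scatter), are therefore read against (the limit of > 50000 nM in this assay, at which 2 of the 3 values shown sit). The step that the two limits leave unreadable from compound 1 to compound 2 cannot be sized at all.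

Compound 4 `CCOC(=O)C1=Cc2ccc(OC)cc2OC1c1cc(OC)c(OC)c(OC)c1` is the next change: ethoxy in place of anilino on a carbonyl carbon. This removes the anilino group whose arrival from piperidin-1-yl gave the only readable gain, and leaves ethoxycarbonyl, which, like hydroxymethyl in compound 1 and (piperidin-1-yl)carbonyl in compound 2, lacks an aromatic ring on that side. The two measured steps onto compound 3 both point the other way, so compound 4 is expected to move back toward the limit, estimated as a 2.9-fold higher number from compound 3 to compound 4 (0.46 log units; beyond the scatter). The expected value for compound 4 in this assay is 50000 nM, within 15000 nM to 160000 nM, with a fair chance that only a limit is reported.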

Compound 4, half-maximal inhibitory concentration: 25000 nM
Compound 4: middle estimate off by 2.0-fold (0.30 log units), on the high side; the range from low to high includes it.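

In this assay the new result is a 1.4-fold higher number from compound 3 to compound 4 (0.15 log units; within the scatter), so at this carbonyl carbon ethoxy and anilino cannot be told apart, and a readable number does not depend on the six-membered aromatic ring or the hydrogen-bond donor of anilino. A readable number is thus no longer tied to phenylcarbamoyl alone: ethoxycarbonyl, with no ring, also gives one, while (piperidin-1-yl)carbonyl in compound 2 and hydroxymethyl in compound 1 remain at a limit. The steps of an at least 2.0-fold lower number from compound 2 to compound 4 (0.30 log units; that floor lies within the scatter) and an at least 2.0-fold lower number from compound 1 to compound 4 (0.30 log units; that floor lies within the scatter) give only floors, so the true distance from those two limits stays unknown, and both steps are read against a limit: the limit of > 50000 nM in this assay, at which 2 of the 4 values shown sit.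

Still open, going by these compounds, is whether a carboxylic acid, a primary amide or a longer ester such as butoxycarbonyl or benzyloxycarbonyl on this double-bonded ring carbon would stay in the same range as ethoxycarbonyl and phenylcarbamoyl. With only two actual numbers in the series, the compounds shown also leave open whether any group at this place can give a number clearly lower than those of compound 3 and compound 4.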